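The compounds below may be only part of what the source reports. "The series", "measured", "known", "first", "only" and "open" are said of these compounds alone.

Compound 2, with the structure `O=C1C(=O)N(CCCn2cc(COc3cc(=O)oc4ccccc34)nn2)c2ccc(I)cc21`, is measured in a functional assay on COLO 205 cells (Homo sapiens) for inhibition, read by sulforhodamine B assay, with a stated time of 48 h, tested at 50 uM (on this read-out higher numbers stand for more inhibition of growth at the one concentration tested and lower numbers for less inhibition of growth), and gives 56%. Among the three compounds measured so far, compound 2 stands second highest. Its nearest neighbour is compound 1, `O=C1C(=O)N(CCCCn2cc(COc3cc(=O)oc4ccccc34)nn2)c2ccc(F)cc21`, which in this assay gives 64%; the two numbers lie within the scatter of each other, so they cannot be told apart. Its furthest neighbour is compound 3, `O=C1C(=O)N(CCCCn2cc(COc3cc(=O)oc4ccccc34)nn2)c2ccc([N+](=O)[O-])cc21`, which gives 45%, a number beyond the scatter below compound 2.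

Compound 4 is `O=C1C(=O)N(CCCn2cc(COc3cc(=O)oc4ccccc34)nn2)c2ccc(Cl)cc21` and is not yet measured. It differs from compound 2 in one place: chloro in place of iodo on an aromatic carbon. Going by the values given here, the only measured step, a number 19 percentage points lower from compound 1 to compound 3 (beyond the scatter), swaps a fluoro for a nitro, not one halo group for another, so it does not bear directly on this change. Compound 1 and compound 2 differ in two places, and their numbers show only that fluoro and iodo on a different chain length give values within the scatter of each other.

Among the compounds with values here, with no measured step of the same kind, a step of a number 1 percentage points higher from compound 2 to compound 4 (within the scatter) is expected, none beyond the scatter. Compound 4 is therefore estimated at 57%, between 42% and 72%.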

Compound 4, percent growth inhibition at one concentration: 67%
Compound 4: the middle estimate sits 10 percentage points below what was measured; low and high end bracket the measured number.
By their numbers in this assay, from the lowest: compound 3; then compounds 2, 1 and 4 (each within the scatter of the next, the first and the last beyond it).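

In this assay, the change from iodo to chloro on this aromatic carbon of the shared core gives a number 11 percentage points higher from compound 2 to compound 4 (beyond the scatter), so this exchange of one halogen for another does move the number. This is the first listed step in which a halogen is the only difference between two compounds, and it shows that such a small swap at this position can exceed the scatter. No measurement at hand accounts for the difference between these two groups.

The compounds shown leave open how a bromo group, a methoxy group or an amine would read on this same aromatic carbon. They also leave open whether chloro in place of iodo would give a similar step on the chain carried by compound 1 and compound 3.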